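Three limits and one open bromophenol

The source may report more compounds than this note shows. Statements on the series, on what has been measured and on what is new or still open speak of the compounds shown alone.

Measured so far in a physicochemical assay for solubility (a lower number here means a less soluble compound, a higher number a more soluble compound), are these compounds:
- compound 1 `O=C(O)c1ccc(C(=O)/C(=C\c2ccc([N+](=O)[O-])cc2F)SCc2ccc(Br)cc2)cc1` gives < 1000 ug/mL as a limit
- compound 2 `O=C(O)c1ccc(C(=O)/C(=C\c2ccc(Br)c([N+](=O)[O-])c2)SCc2ccc(Cl)cc2)cc1` gives < 1000 ug/mL as a limit
- compound 3 `O=C(O)c1ccc(C(=O)/C(=C\c2ccc(F)c([N+](=O)[O-])c2)SCc2ccc(F)cc2)cc1` gives < 1000 ug/mL as a limit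

Compound 1 stands at a limit of the assay and not at a number (< 1000 ug/mL). The set as a whole gives no more than that (the limit of < 1000 ug/mL in this assay, at which 3 of the 3 values shown sit). Compound 4 `O=C(O)c1ccc(C(=O)/C(=C\c2ccc(O)c(Br)c2)SCc2ccc(Br)cc2)cc1` has 3-bromo-4-hydroxyphenyl in place of 2-fluoro-4-nitrophenyl on a double-bonded chain carbon bound to a double-bonded chain carbon. Within the data shown here, no measured step exists to guide the size of this one. The expected move in this assay is small and slightly downward, with an estimated size of a step that the limit leaves unreadable from compound 1 to compound 4 and nothing expected beyond the scatter. For compound 4 the estimate is 600 ug/mL with an expected range of 150 ug/mL to 1200 ug/mL and another limit is a likely report.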

Compound 4, solubility: < 1000 ug/mL
Compound 4: no number, only a limit; the forecaster's own chance of this, stated with the estimate: 80%; the middle value does not contradict the limit.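

Among these compounds, compound 4 gives only a limit, < 1000 ug/mL, and no step between compound 1 and compound 4 can be read in this assay. How compound 1, compound 2, compound 3 and compound 4 rank against one another stays open: the limit of < 1000 ug/mL in this assay, at which 4 of the 4 values shown sit.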